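Swapping a Cyclopentyl Ring for a Hydroxyethyl Chain

The source may hold more compounds than are shown below. What is called first, only, known or untested is meant among the compounds shown, and "the series" means these compounds.

Compound 1, `CN(c1ccnc(Nc2ccc(C#N)cc2)n1)c1c(F)cc(-c2ccc(C#N)cc2)cc1F`: in an ADME assay on MT4 cells (Homo sapiens) for cytotoxicity, read by MTT assay, with a stated time of 5 days (a lower number here means that less compound is tolerated, a higher number that more compound is tolerated), compound 1 gives 148000 nM.
Compound 2, `N#Cc1ccc(Nc2nccc(N(CC3CCCC3)c3c(F)cc(-c4ccc(C#N)cc4)cc3F)n2)cc1`: in this assay compound 2 reaches only a limit of the assay, > 247000 nM.

These two compounds differ in one place, and the step of an at least 1.6-fold higher number from compound 1 to compound 2 (0.22 log units; that floor lies within the scatter) gives only a floor. Compound 2 therefore stands at the limit of > 247000 nM in this assay, at which 1 of the 2 values shown sits, so its true number is not known, only that it lies beyond that mark. Compound 3, `CC(O)CN(c1ccnc(Nc2ccc(C#N)cc2)n1)c1c(F)cc(-c2ccc(C#N)cc2)cc1F`, has not yet been measured. It differs from compound 2 by 1-hydroxyethyl in place of cyclopentyl on a saturated chain carbon bound to a nitrogen on an aromatic ring. Among the compounds with values here, the only measured step that bears on this change is the one from hydrogen to cyclopentyl, an at least 1.6-fold higher number from compound 1 to compound 2 (0.22 log units; that floor lies within the scatter), and its floor lies within the usual scatter. The new group is a short chain with a hydroxyl in place of a carbon ring, so no step beyond the scatter is expected in this assay, in either direction. Compound 3 is expected to give about 200000 nM, with a range from 100000 nM to 400000 nM, and it may again reach only a limit. The step this estimate implies, an at least 1.2-fold lower number from compound 2 to compound 3 (0.09 log units; that floor lies within the scatter), is expected to stay within the scatter.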

Compound 3, half-maximal cytotoxic concentration: 9800 nM
Beside the measured number, compound 3's estimate is 20-fold (1.31 log units) above it, outside the stated range (below it).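

In this assay, the group on a saturated chain carbon bound to a nitrogen on an aromatic ring clearly matters: 1-hydroxyethyl gives an at least 25-fold lower number from compound 2 to compound 3 (1.40 log units; beyond the scatter) when it replaces cyclopentyl, and a 15-fold lower number from compound 1 to compound 3 (1.18 log units; beyond the scatter) when it replaces hydrogen. Both steps lie beyond the scatter, while the earlier change from hydrogen to cyclopentyl gave only a floor within it, so the lower number follows the arrival of 1-hydroxyethyl; cells tolerate less of compound 3 than of either of the other two compounds. The step from compound 2 is itself only a floor, and its true size may be larger: the limit of > 247000 nM in this assay, at which 1 of the 3 values shown sits.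

Going by these compounds, what remains open is whether the oxygen or the carbon chain of 1-hydroxyethyl goes with the lower number, and a plain ethyl chain in the same place would separate the two. The compounds shown also cannot tell whether an amine or a carboxylic acid there would lower the number in the same way, and nothing measured here explains the drop.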